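The compounds below may be only part of what the source reports. "The series", "measured", "known", "first", "only" and "open" are said of these compounds alone.

The shared core of compound 3 `COc1cccc2cc(C(=O)NC3CCCCC3)c(=N)oc12` bears an amide carrying a cyclohexyl group. In an assay on HEK293 cells for displacement of a labelled ligand from adenosine receptor A2b (Homo sapiens), read by scintillation counting, with a stated time of 30 min, tested at 10 uM (on this read-out higher numbers stand for more inhibition at the one concentration tested (going by the name of the read-out) and lower numbers for less inhibition), compound 3 reaches > 70%, which is a limit of the assay and not a number. Going by the values given here, it is the one value at the limit of > 70% in this assay, at which 1 of the 3 values shown sits. Compound 4 `COCCNC(=O)c1cc2cccc(OC)c2oc1=N` differs from compound 3 by 2-methoxyethyl in place of cyclohexyl on an amide-type nitrogen. Among the compounds with values here, no measured step matches this change exactly. The nearest comparison comes from compound 1 `COc1cccc2cc(C(=O)NCC(=O)O)c(=O)oc12` and compound 2 `COCCNC(=O)c1cc2cccc(OC)c2oc1=O`, whose amide substituent was also altered: that step was a number 17 percentage points lower from compound 1 to compound 2 (beyond the scatter), and in this assay compound 1 gives 35% while compound 2 gives 18%. Compound 2 carries the same 2-methoxyethyl group that enters in compound 4 and shows the lower of those two readings. The step from compound 3 to compound 4 is therefore expected to be downward, roughly a number at least 35 percentage points lower from compound 3 to compound 4 (beyond the scatter), though the starting point is only a limit. Compound 4 is accordingly estimated to give 35% in this assay, with a likely range from 10% to 65%.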

Compound 4, a percentage reported as inhibition, at one concentration (the size of the read-out at that concentration, not a potency): 43%
Compound 4: middle estimate off by 8 percentage points, on the low side; measured number inside the range.
By their numbers in this assay, from the lowest: compound 2; then compounds 1 and 4 (each within the scatter of the next). At a limit, above all of these: compound 3.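

In this assay, putting 2-methoxyethyl in place of cyclohexyl on the amide-type nitrogen gives a number at least 27 percentage points lower from compound 3 to compound 4 (beyond the scatter). The earlier pair had shown a change only from one open chain to another, whereas this step shows that the reading at this position also responds when a six-membered carbon ring gives way to an open chain. Compound 3 reads > 70%, which is a limit of the assay and not a number, so the full size of the step stays unknown: the limit of > 70% in this assay, at which 1 of the 4 values shown sits.

The change removes the ring and brings in an ether oxygen at once, and the compounds shown do not separate the two; a plain butyl chain or a tetrahydropyranyl ring on the same nitrogen would bear on this. As far as these compounds go, how a terminal amine or carboxylic acid on the chain would read on the core of compound 4 also remains open.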